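The source may report more compounds than this note shows. Statements on the series, on what has been measured and on what is new or still open speak of the compounds shown alone.

Compound 1 `CC[C@@H](Nc1c(C#N)c(-c2ccc(-c3cccc(Cl)c3F)cc2)nc2cnccc12)C(N)=O` gives 3.1.
Compound 2 `CCOc1ccccc1-c1ccc(-c2nc3cnccc3c(C[C@H](C)C(=O)O)c2C#N)cc1` gives 2.2.
Compound 3 `CC[C@@H](Nc1c(C#N)c(-c2ccc(-c3cccc(C)c3F)cc2)nc2cnccc12)C(=O)O` gives 2.1.

In a physicochemical assay for lipophilicity, read by HPLC, at pH 7.5 (a lower number here means a more polar compound, a higher number a more lipophilic compound), compound 1 gives 3.1, the highest of the three numbers. Compound 2 stands nearest to it, at a distance beyond the usual scatter, and compound 3 stands furthest, also beyond the scatter. Compound 2 and compound 3 lie close to each other. For the measured compounds named here, no single-point step between measured compounds is available, so the account rests on these values alone.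

Compound 4 `CC[C@@H](Nc1c(C#N)c(-c2ccc(-c3ccccc3C(C)C)cc2)nc2cnccc12)C(N)=O` has not yet been measured in this assay. It differs from compound 1 in one place: 2-isopropylphenyl in place of 3-chloro-2-fluorophenyl on an aromatic carbon.

Going by the values given here, no measured pair shows this exchange, so its effect is an expectation only. Because compound 1 already gives 3.1, and the group that enters carries more carbon than the one that leaves, the number for compound 4 is expected to rise by a step beyond the scatter, a number 0.60 log units higher from compound 1 to compound 4 (beyond the scatter). The value of compound 4 is estimated at 3.7, with a range from 3.3 to 4.2.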

Compound 4, distribution coefficient: 3.5
Compound 4: middle estimate off by 0.20 log units, on the high side, and the stated range covers the measured number.
By their numbers in this assay, from the lowest: compounds 3 and 2 (each within the scatter of the next); then compound 1; then compound 4.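

With compound 4, the position on the aromatic carbon para to a large group gains its first single-place step in this assay: a number 0.40 log units higher from compound 1 to compound 4 (beyond the scatter). The earlier compounds shown here could not isolate this position, as none of them differed in one place, whereas here 2-isopropylphenyl in place of 3-chloro-2-fluorophenyl moves the number beyond the scatter while the rest of compound 1 stays the same. Both groups are uncharged and have no hydrogen-bond donors or acceptors, and nothing available accounts for the step.

The compounds shown leave open whether an all-carbon group without the isopropyl branch, such as a 2-methylphenyl or 2-tert-butylphenyl group, would give a similar step. They also leave open how a dimethylamino or hydroxyl group at this position would read, and whether the same exchange gives the same step with a carboxylic acid in place of the amide.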